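Swapping Fluoro for Trifluoromethyl on a Hydroxy Core

The source may hold more compounds than are shown below. What is called first, only, known or untested is meant among the compounds shown, and "the series" means these compounds.

Compound 1 `Fc1ccc(-c2ccc(-c3ccc(-c4nc5ccccc5[nH]4)cc3)cc2)cc1` carries a fluoro group at the far end of its chain of rings. In a functional assay on DWD cells (Homo sapiens) for inhibition, read by sulforhodamine B assay (on this read-out lower numbers stand for stronger inhibition of growth and higher numbers for weaker inhibition of growth), compound 1 gives 35600 nM. Compound 2 `FC(F)(F)c1ccc(-c2ccc(-c3ccc(-c4nc5ccccc5[nH]4)cc3)cc2)cc1` differs from compound 1 by trifluoromethyl in place of fluoro on an aromatic carbon; in this assay compound 2 gives 100000 nM, and a 2.8-fold higher number from compound 1 to compound 2 (0.45 log units; beyond the scatter). Compound 3 `Oc1cccc2[nH]c(-c3ccc(-c4ccc(-c5ccc(F)cc5)cc4)cc3)nc12` differs from compound 1 in its core by hydroxy in place of hydrogen on an aromatic carbon; in this assay compound 3 gives 22200 nM, and a 1.6-fold lower number from compound 1 to compound 3 (0.21 log units; within the scatter). Compound 4 `Oc1cccc2[nH]c(-c3ccc(-c4ccc(-c5ccc(C(F)(F)F)cc5)cc4)cc3)nc12` has not yet been measured. It differs from compound 3 by trifluoromethyl in place of fluoro on an aromatic carbon; the surroundings of that place match those in the step from compound 1 to compound 2, so this is the same change made on the hydroxy-bearing core. The step expected from compound 3 to compound 4 in this assay is a 2.7-fold higher number from compound 3 to compound 4 (0.43 log units; beyond the scatter), resting on the measured 2.8-fold higher number from compound 1 to compound 2 (0.45 log units; beyond the scatter). Compound 4 is therefore estimated at 60000 nM, expected to lie between 28000 nM and 130000 nM.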

Compound 4, concentration for 50% growth inhibition: 3180 nM
Compound 4: middle estimate off by 19-fold (1.28 log units), on the high side, outside the stated range (below it).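

Trifluoromethyl in place of fluoro did not carry over from one core to the other: on the hydroxy-bearing core the change gave a 7.0-fold lower number from compound 3 to compound 4 (0.84 log units; beyond the scatter), opposite in direction to the earlier step: the same change on two cores in this assay, a 2.8-fold higher number (0.45 log units; beyond the scatter) from compound 1 to compound 2 and a 7.0-fold lower number (0.84 log units; beyond the scatter) from compound 3 to compound 4, 20-fold (1.29 log units) apart, beyond the scatter of two such steps

Read the other way, hydroxy in place of hydrogen gave a 31-fold lower number from compound 2 to compound 4 (1.50 log units; beyond the scatter), so the size of that step depends on the end group present: the same change on two cores in this assay, a 1.6-fold lower number (0.21 log units; within the scatter) from compound 1 to compound 3 and a 31-fold lower number (1.50 log units; beyond the scatter) from compound 2 to compound 4, 20-fold (1.29 log units) apart, beyond the scatter of two such steps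

The two changes therefore do not add up independently in these compounds, but four compounds cannot show why, or whether this holds beyond this one pair of groups.

From the compounds shown here alone, whether a chlorine atom, a methoxy group or a nitrile in place of trifluoromethyl would behave the same way on the hydroxy-bearing core stays open. So does whether an amine in place of the hydroxy group would give a similar result.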